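The source may hold more compounds than are shown below. What is called first, only, known or untested is meant among the compounds shown, and "the series" means these compounds.

Compound 3 `CCCc1cc(N)c2cc(NC(=O)/C=C/c3cccc(Cl)c3)ccc2n1` gives the highest number of the three measured compounds in an assay on isolated protein for displacement of a labelled ligand from melanin-concentrating hormone receptor 1 (Homo sapiens) (on this read-out lower numbers stand for stronger inhibition and higher numbers for weaker inhibition), at 1100 nM. Compound 1 `CCCc1cc(N)c2cc(NC(=O)/C=C/c3ccc(SC)cc3)ccc2n1` gives 9 nM in this assay, and compound 2 `CCCc1cc(N)c2cc(NC(=O)/C=C/c3ccc(CC)cc3)ccc2n1` gives 1.4 nM. The change to compound 4 `CCCc1cc(N)c2cc(NC(=O)/C=C/c3ccc(I)cc3)ccc2n1` is 4-iodophenyl in place of 3-chlorophenyl on a double-bonded chain carbon bound to a double-bonded chain carbon. Among the measured compounds shown here, two measured steps bear on it, each putting 3-chlorophenyl in place of 4-(methylsulfanyl)phenyl or 4-ethylphenyl: a 120-fold higher number from compound 1 to compound 3 (2.09 log units; beyond the scatter) and a 790-fold higher number from compound 2 to compound 3 (2.90 log units; beyond the scatter). The change to compound 4 runs that kind of swap backwards, returning to a phenyl of the 4-substituted type that compound 1 and compound 2 carry, so a large fall in this assay is expected for compound 4, a 180-fold lower number from compound 3 to compound 4 (2.26 log units; beyond the scatter). Compound 4 is therefore estimated at 6 nM, with a range from 1.5 nM to 40 nM.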

Compound 4, half-maximal inhibitory concentration: 2.3 nM
Compound 4: the middle estimate sits 2.6-fold (0.42 log units) above what was measured; the measured number falls inside the stated range.
By their numbers in this assay, from the lowest: compounds 2 and 4 (each within the scatter of the next); then compound 1; then compound 3.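

In this assay, the change to 4-iodophenyl gives a 480-fold lower number from compound 3 to compound 4 (2.68 log units; beyond the scatter), so a phenyl carrying a halogen is not poor as such. Iodo cannot be told apart from ethyl, with a 1.6-fold higher number from compound 2 to compound 4 (0.22 log units; within the scatter), and it does better than methylsulfanyl, with a 3.9-fold lower number from compound 1 to compound 4 (0.59 log units; beyond the scatter). Nothing measured here explains these differences. The change from 3-chlorophenyl to 4-iodophenyl swaps both the halogen and where it sits on the phenyl, so the compounds shown cannot separate those two changes. Compounds carrying 4-chlorophenyl and 3-iodophenyl would tell them apart.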